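Dimethylamino for dimethoxy on the pyridinone aryl group

The source may report more compounds than this note shows. Statements on the series, on what has been measured and on what is new or still open speak of the compounds shown alone.

Measured so far:
compound 1, `Cc1cc(O)c(C(C)C)cc1-c1cc(-c2ccccc2)c(C#N)c(=O)[nH]1`, with 41%;
compound 2, `COc1ccc(-c2cc(-c3cc(C(C)C)c(O)cc3C)[nH]c(=O)c2C#N)cc1OC`, with 61%.

Among the measured compounds shown here, compound 2 gives the higher of the two numbers in a functional assay for inhibition, tested at 100 ug/mL; on this read-out higher numbers stand for a stronger effect at the one concentration tested and lower numbers for a weaker effect; the only other measured compound, compound 1, sits a number 20 percentage points higher from compound 1 to compound 2 (beyond the scatter) away, a step beyond the scatter. Compound 3, `Cc1cc(O)c(C(C)C)cc1-c1cc(-c2ccc(N(C)C)cc2)c(C#N)c(=O)[nH]1`, is not yet measured. It differs from compound 2 in one place: 4-(dimethylamino)phenyl in place of 3,4-dimethoxyphenyl on an aromatic carbon. For the measured compounds named here, the single measured step, from phenyl to 3,4-dimethoxyphenyl, brought the gain seen in compound 2, but no step between two substituted phenyl groups has been measured, so the change to compound 3 has no direct precedent. Keeping a substituted aryl group in the same place, compound 3 is expected to stay near compound 2, with the step of a number 6 percentage points lower from compound 2 to compound 3 (within the scatter) expected to lie within the scatter. The estimated value for compound 3 is 55%, within the range 35% to 75%.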

Compound 3, a percentage reported as inhibition, at one concentration (the size of the read-out at that concentration, not a potency): 68%
The estimate for compound 3 lay 13 percentage points below the measured number; measured number inside the range.
By their numbers in this assay, from the lowest: compound 1; then compounds 2 and 3 (each within the scatter of the next).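

In this assay, replacing 3,4-dimethoxyphenyl with 4-(dimethylamino)phenyl gives a number 7 percentage points higher from compound 2 to compound 3 (within the scatter) and so does not separate the two groups, which shows that this position accepts a different substituted phenyl group, with nitrogen in place of the two oxygens, and keeps the read-out at the same level. Against the plain phenyl group, dimethylamino in place of hydrogen gives a number 27 percentage points higher from compound 1 to compound 3 (beyond the scatter) and so, for the second time, a substituted phenyl group stands clear of the unsubstituted one, here with a single substituent. Nothing available explains why these two groups give such similar read-outs.

From the compounds shown here alone, it remains open whether a 4-methoxyphenyl or a 4-aminophenyl group would hold this level. A carboxylic acid on the same phenyl ring is equally untested among the compounds shown, so how far this tolerance extends is unknown.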